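The source may report more compounds than this note shows. Statements on the series, on what has been measured and on what is new or still open speak of the compounds shown alone.

Compound 1 `CCCSc1nc(N/N=C/c2ccc(Cl)cc2)c2nnn(Cc3ccccc3)c2n1`: > 64000 nM (a limit)
Compound 2 `CCCSc1nc(N/N=C/c2cccs2)c2nnn(Cc3ccccc3)c2n1`: > 64000 nM (a limit)

In a functional assay on ECa-109 cells (Homo sapiens) for antiproliferative activity, read by MTT assay, with a stated time of 72 h (a higher number here means a weaker inhibitor, a lower number a stronger inhibitor), compound 2 gives > 64000 nM, which is a limit and not a number. Both measured compounds sit at the limit of > 64000 nM in this assay, at which 2 of the 2 values shown sit. Compound 3 `CCCSc1nc(N/N=C(\C)c2ccc(Br)cc2)c2nnn(Cc3ccccc3)c2n1` differs from compound 2 by one change: a group of 10 heavy atoms (8 carbon, 1 nitrogen, 1 bromine; one six-membered aromatic ring of carbon only) in place of a group of 7 heavy atoms (5 carbon, 1 nitrogen, 1 sulfur; one five-membered aromatic ring with 1 hetero atom), on a nitrogen on an aromatic ring. Among the compounds with values here, the only measured step, a step that the two limits leave unreadable from compound 1 to compound 2, offers no size to carry over. No step beyond the scatter is therefore expected in this assay, and the estimated step is a number no higher from compound 2 to compound 3 (the limit leaves the size open). Compound 3 is expected at 64000 nM, with an estimated range of 25000 nM to 128000 nM.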

Compound 3, half-maximal inhibitory concentration: 4670 nM
Estimate against measurement, compound 3: 14-fold (1.14 log units) above, outside the stated range (below it).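

In this assay, the group on this nitrogen can move the result out of the inactive range, with an at least 13-fold lower number from compound 2 to compound 3 (1.13 log units; beyond the scatter) and an at least 13-fold lower number from compound 1 to compound 3 (1.13 log units; beyond the scatter). The group of 10 heavy atoms, with its six-membered aromatic ring of carbon only and its bromine, is the first shown to give a readable value. The step between compound 1 and compound 2 cannot be read, because both are limits and not numbers: the limit of > 64000 nM in this assay, at which 2 of the 3 values shown sit.

The group in compound 3 differs from that in compound 1 by both its bromine and one more carbon, so which of these matters remains unresolved. Going by these compounds, whether a fluorine or an amine in place of the bromine would keep this activity also stays open.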